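Lengthening the hydroxamate chain of compound 2

The source may report more compounds than this note shows. Statements on the series, on what has been measured and on what is new or still open speak of the compounds shown alone.

Measured compounds:
- compound 1, `O=C(NO)c1ccc(Cn2nc(-c3ccc(F)cc3)cc2Cc2ccccc2)cc1`: in an assay on cells for inhibition of protein deacetylase HDAC6 (Homo sapiens), read by fluorescence, with stated times of 15 min and 60 min (a higher number here means a weaker inhibitor, a lower number a stronger inhibitor), compound 1 gives 326 nM
- compound 3, `O=C(NO)c1ccc(Cn2nc(Cc3ccccc3)cc2-c2ccc(F)cc2)cc1`: in this assay compound 3 gives 420 nM
- compound 2, `O=C(CCNC(=O)c1cc(-c2ccc(F)cc2)[nH]n1)NO`: in this assay compound 2 reaches only the limit > 5000 nM

Compound 1 and compound 3 share a benzylic hydroxamate on the same core, and their two values lie within the usual scatter of each other. Among the compounds with values here, compound 2 stands apart: for it the assay reports only a limit, not a number, and it is the one of the three values that sits at the limit of > 5000 nM in this assay, at which 1 of the 3 values shown sits.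

Compound 4, `O=C(CCCCCNC(=O)c1cc(-c2ccc(F)cc2)[nH]n1)NO`, differs from compound 2 in one place: 3-(hydroxycarbamoyl)propyl in place of hydroxycarbamoyl on a saturated chain carbon, two bonds along the chain from an amide-type nitrogen. Within the data shown here, no measured pair shows this kind of chain lengthening, so the size of the step from compound 2 to compound 4 cannot be read from the data. Given that compound 2 sits only at a limit, the step from compound 2 to compound 4 is expected to be at most modest, most likely toward a stronger inhibitor, and it could well stay within the scatter, as an at least 1.6-fold lower number from compound 2 to compound 4 (0.22 log units; that floor lies within the scatter) states. Compound 4 is accordingly estimated at 3000 nM in this assay, between 700 nM and 12000 nM.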

Compound 4, half-maximal inhibitory concentration: 29 nM
Compound 4: middle estimate off by 100-fold (2.01 log units), on the high side, and the stated range ends above it.
By their numbers in this assay, from the lowest: compound 4; then compounds 1 and 3 (each within the scatter of the next). At a limit, above all of these: compound 2.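

Among the earlier compounds no pair differed in one place, so none showed how much this chain matters. At this position, on a saturated chain carbon, two bonds along the chain from an amide-type nitrogen, 3-(hydroxycarbamoyl)propyl in place of hydroxycarbamoyl gives in this assay an at least 170-fold lower number from compound 2 to compound 4 (2.23 log units; beyond the scatter), so chain length here is a strong lever on the read-out. The true size of the step stays unknown and this figure is only a floor, because compound 2 stands at a limit and not at a number: the limit of > 5000 nM in this assay, at which 1 of the 4 values shown sits.

The compounds shown hold only these two chain lengths, so they leave open at which intermediate length the number falls and whether a longer chain lowers it further. They also leave open whether the hydroxycarbamoyl end is needed at this length, which a carboxylic acid in its place would test.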